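Notes on amine substitution and cytotoxicity in the series

The source may hold more compounds than are shown below. What is called first, only, known or untested is meant among the compounds shown, and "the series" means these compounds.

Of the compounds shown here, two have been measured in a toxicity assay on A549 cells (Homo sapiens) for cytotoxicity, read by luminescence and CellTiter-Glo, with a stated time of 48 h; on this read-out higher numbers stand for lower toxicity in this test and lower numbers for higher toxicity in this test. Compound 1, `CCCCOc1ccc(-c2nc3ncccn3c2NC2CCCCCC2)cc1`, gives 26000 nM in this assay. Compound 2, `CCCCOc1ccc(-c2nc3ncccn3c2N)cc1`, returns only a limit in this assay, > 100000 nM. Among the compounds with values here, the single step between the two, an at least 3.8-fold higher number from compound 1 to compound 2 (0.58 log units; beyond the scatter), places compound 2 at the less toxic end of what is known, though its position is fixed only by the limit of > 100000 nM in this assay, at which 1 of the 2 values shown sits, and not by a number.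

Compound 3, `CCCCOc1ccc(-c2nc3ncccn3c2NCc2ccccn2)cc1`, has not yet been measured in this assay. It differs from compound 2 by (pyridin-2-yl)methyl in place of hydrogen on a nitrogen on an aromatic ring. Within the data shown here, the only measured step that bears on this change is an at least 3.8-fold higher number from compound 1 to compound 2 (0.58 log units; beyond the scatter), read in the opposite direction: putting a substituent onto that nitrogen went with a lower number in this assay. A modest move toward a lower number is therefore expected for compound 3, with the size uncertain since compound 2 itself is known only as a limit. Compound 3 is expected to give 60000 nM in this assay, within a range of 20000 nM to 150000 nM. The expected step is an at least 1.6-fold lower number from compound 2 to compound 3 (0.22 log units; that floor lies within the scatter).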

Compound 3, half-maximal cytotoxic concentration: > 100000 nM
Compound 3: a limit, no number; the forecaster's own chance of this, stated with the estimate: 40%; at least 1.6-fold (0.22 log units) between middle value and limit.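

Notes on the result: In this assay, (pyridin-2-yl)methyl in place of cycloheptyl on the nitrogen gives an at least 3.8-fold higher number from compound 1 to compound 3 (0.58 log units; beyond the scatter). A substituent on this nitrogen therefore does not by itself go with a lower number: compound 3 goes against the reading suggested by the first two compounds, and among the three only compound 1, with cycloheptyl, gives a number rather than a limit. The results for compound 2 and compound 3 are both limits, so the step between them cannot be read and neither can be placed relative to the other: the limit of > 100000 nM in this assay, at which 2 of the 3 values shown sit.

From the compounds shown here alone, it remains open where a benzyl group, which keeps a six-membered aromatic ring on the same kind of link but has no ring nitrogen, would fall on this read-out, and so whether the ring nitrogen of the (pyridin-2-yl)methyl group matters here at all. A cyclohexyl or cyclopentyl group on the same nitrogen would show whether the lower number of compound 1 is particular to cycloheptyl or is shared by other saturated rings.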